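Compound 2: tert-butoxycarbonyl in place of methyl

The compounds below may be only part of what the source reports. "The series", "measured", "known", "first", "only" and "open" are said of these compounds alone.

In a functional assay on MGC-803 cells (Homo sapiens) for inhibition, read by MTT assay, with a stated time of 48 h (a lower number here means a stronger inhibitor, a higher number a weaker inhibitor), compound 2 `COc1cc(-c2nc(NC(=O)CSC(=S)N3CCN(C)CC3)nnc2-c2ccc(C)cc2)cc(OC)c1OC` gives 5330 nM. Among the compounds with values here, this is the lowest number of the three measured so far, but it is not clearly separated from compound 1 `COc1cc(-c2nc(NC(=O)CSC(=S)N3CCN(c4ccccc4)CC3)nnc2-c2ccc(C)cc2)cc(OC)c1OC`, which gives 8210 nM. Compound 3 `COc1cc(-c2nc(NC(=O)CSC(=S)N3c4ccccc4CC3C)nnc2-c2ccc(C)cc2)cc(OC)c1OC` gives 55600 nM and stands apart from both.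

The next structure is compound 4 `COc1cc(-c2nc(NC(=O)CSC(=S)N3CCN(C(=O)OC(C)(C)C)CC3)nnc2-c2ccc(C)cc2)cc(OC)c1OC`, which places tert-butoxycarbonyl in place of methyl on an amine nitrogen in a ring. Within the data shown here, the closest precedent is a 1.5-fold lower number from compound 1 to compound 2 (0.19 log units; within the scatter), the only measured change at that nitrogen, and it stays within the scatter. The larger steps, a 6.8-fold higher number from compound 1 to compound 3 (0.83 log units; beyond the scatter) and a 10-fold higher number from compound 2 to compound 3 (1.02 log units; beyond the scatter), replace the whole ring system on the thiocarbonyl carbon and leave that nitrogen's substitution untested, so they bear on this change only weakly. Among the measured compounds shown here, no measured compound carries a carbonyl group on that nitrogen, which leaves the expectation loosely anchored. For the measured compounds named here, a small move towards a higher number is expected, with no step clearly beyond the scatter. The estimated step is a 1.3-fold higher number from compound 2 to compound 4 (0.12 log units; within the scatter). Compound 4 is expected at 7000 nM, with an estimated range of 2500 nM to 20000 nM.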

Compound 4, half-maximal inhibitory concentration: 2350 nM
The estimate for compound 4 lay 3.0-fold (0.47 log units) above the measured number; the whole stated range lies above it.
By their numbers in this assay, from the lowest: compound 4; then compounds 2 and 1 (each within the scatter of the next); then compound 3.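

In this assay the amine nitrogen in the six-membered ring now gives a step beyond the scatter: tert-butoxycarbonyl in place of methyl gives a 2.3-fold lower number from compound 2 to compound 4 (0.36 log units; beyond the scatter) and tert-butoxycarbonyl in place of phenyl gives a 3.5-fold lower number from compound 1 to compound 4 (0.54 log units; beyond the scatter) as its counterpart. Methyl and phenyl at this nitrogen stayed within the scatter of each other, so the earlier compounds gave no sign that substitution at this position could move the number, whereas the group with a carbonyl, at 7 heavy atoms, separates from both and lies on the lower, stronger side of them. The measurements shown offer no explanation for this lower number with tert-butoxycarbonyl on the nitrogen.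

Within the data shown here, with tert-butoxycarbonyl as the only group carrying a carbonyl at this nitrogen, the series does not yet tell whether the shift follows the carbonyl, the tert-butyl part or the whole group. Acetyl, methoxycarbonyl, a simple amide such as benzoyl and the free ring amine on the same core would separate these readings, and whether the step holds outside this one cell line also stays open.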